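This account rests on a few compounds, and the source may have more. Where it says the series, first, only, none or still open, it means among the compounds named here.

Compound 1 `CCN(CC)CCCNc1nc(-c2ccc(NC(=O)Nc3ccccc3)cc2)nc2ccsc12` gives 980 nM in a functional assay on MKN-45 cells (Homo sapiens) for cytotoxicity, read by MTT assay, with a stated time of 72 h; on this read-out lower numbers stand for stronger inhibition and higher numbers for weaker inhibition. Compound 2 `CCN(CC)CCCNc1nc(-c2ccc(NC(=O)Nc3ccc(Cl)cc3)cc2)nc2ccsc12` gives 180 nM in this assay. Between them stands (chloro in place of hydrogen on an aromatic carbon), which made the step of a 5.4-fold lower number from compound 1 to compound 2 (0.74 log units; beyond the scatter). Compound 3 `CCN(CC)CCNc1nc(-c2ccc(NC(=O)Nc3ccccc3Cl)cc2)nc2ccsc12` gives 750 nM in this assay; the difference between its core and the core of compound 1 is not broken down here. Compound 4 `CCN(CC)CCNc1nc(-c2ccc(NC(=O)Nc3ccc(Cl)cc3Cl)cc2)nc2ccsc12` is not yet measured and carries chloro in place of hydrogen on an aromatic carbon. This is the same kind of change as that from compound 1 to compound 2, not the same: in compound 4 the entering chloro sits meta to a chloro group as well as para to a large group. Compound 4 is expected to show a step of about a 4.2-fold lower number from compound 3 to compound 4 (0.62 log units; beyond the scatter), resting on the earlier step of a 5.4-fold lower number from compound 1 to compound 2 (0.74 log units; beyond the scatter). For compound 4 the estimate is 180 nM, expected to fall between 70 nM and 500 nM.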

Compound 4, half-maximal inhibitory concentration: 1520 nM
The estimate for compound 4 lay 8.4-fold (0.93 log units) below the measured number, outside the stated range (above it).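

In this assay, chloro in place of hydrogen, para to a large group, gives a 2.0-fold higher number from compound 3 to compound 4 (0.31 log units; beyond the scatter). Set beside the earlier step, the change does not carry over from one core to the other in size or direction: the same change on two cores in this assay, a 5.4-fold lower number (0.74 log units; beyond the scatter) from compound 1 to compound 2 and a 2.0-fold higher number (0.31 log units; beyond the scatter) from compound 3 to compound 4, 11-fold (1.04 log units) apart, beyond the scatter of two such steps This shows that the earlier step cannot be transferred to this core as a fixed increment, but it does not show whether the gap follows from the chloro group already present in compound 3 or from the other differences between the cores. The compounds shown leave open how a 2,4-dichlorophenyl group behaves on the core of compound 1. They also leave open whether a fluoro or methyl group entering at the same place would follow either step.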